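Swapping the Aniline Substituent on a Fused Tricyclic Core

A few compounds are considered here, and "the series" means these few. Any claim that something is new, unique, unknown or untested is made for them only; others in the source may bear on it.

Measured so far:
compound 1 `Cc1ccc(NC2=CC(=O)c3nc4n(c3C2=O)[C@H]2OC[C@@H](O)[C@H]2OC4)cc1C` — 860 nM
compound 2 `CCOc1ccccc1NC1=CC(=O)c2c(nc3n2[C@H]2OC[C@@H](O)[C@H]2OC3)C1=O` — 2830 nM
compound 3 `O=C1C(Nc2ccccc2F)=CC(=O)c2c1nc1n2[C@H]2OC[C@@H](O)[C@H]2OC1` — 2000 nM

In a functional assay on MGC-803 cells (Homo sapiens) for inhibition, read by sulforhodamine B assay (on this read-out higher numbers stand for weaker inhibition and lower numbers for stronger inhibition), compound 1 gives the lowest number of the three, ahead of compound 3 and compound 2 by margins beyond the scatter. Compound 4 `CCOc1ccccc1NC1=CC(=O)c2nc3n(c2C1=O)[C@H]1OC[C@@H](O)[C@H]1OC3` keeps the core of compound 1 and differs from it in one place: 2-ethoxyphenyl in place of 3,4-dimethylphenyl on an amine nitrogen. Within the data shown here, no measured step exchanges these two groups directly. Among the measured compounds shown here, the only measured step, a 1.4-fold lower number from compound 2 to compound 3 (0.15 log units; within the scatter), lies within the scatter, and compound 2 carries the same 2-ethoxyphenyl on a differently arranged core. Drawing on that, compound 4 is expected to land somewhat weaker than compound 1, a step of a 2.3-fold higher number from compound 1 to compound 4 (0.37 log units; beyond the scatter). The estimate for compound 4 is 2000 nM, with a range from 700 nM to 6000 nM.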

Compound 4, half-maximal inhibitory concentration: 2450 nM
For compound 4 the middle estimate is 1.2-fold (0.09 log units) below the measured one; the measured number falls inside the stated range.
By their numbers in this assay, from the lowest: compound 1; then compounds 3, 4 and 2 (each within the scatter of the next).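

With the core held fixed, the group on the amine nitrogen changes the result: 2-ethoxyphenyl in place of 3,4-dimethylphenyl gives a 2.8-fold higher number from compound 1 to compound 4 (0.45 log units; beyond the scatter) in this assay. Among these compounds, this is the first step at this position that clears the scatter, and it compares the two groups directly on one core. Nothing measured here accounts for the shift.

From the compounds shown here alone, it remains open how 2-fluorophenyl would read on the core of compound 1. Also open, going by these compounds, is whether a single methyl, or an amine on the aromatic ring, would keep the lower number of compound 1.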